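The source may report more compounds than this note shows. Statements on the series, on what has been measured and on what is new or still open speak of the compounds shown alone.

Measured compounds:
Compound 1 `O=C1C=C(Nc2ccccc2)C(=O)c2c1nc1n2[C@H]2OC[C@@H](O)[C@H]2OC1`: 4970 nM
Compound 2 `O=C1C(N2CCCC2)=CC(=O)c2c1nc1n2[C@H]2OC[C@@H](O)[C@H]2OC1`: > 16000 nM, a limit
Compound 3 `O=C1C=C(N2CCCCC2)C(=O)c2c1nc1n2[C@H]2OC[C@@H](O)[C@H]2OC1`: > 8000 nM, a limit

Among the measured compounds shown here, in a functional assay on ECa-109 cells for inhibition, with ECa-109 cell line (Homo sapiens) as the target, read by sulforhodamine B assay (a higher number here means a weaker inhibitor, a lower number a stronger inhibitor), compound 1 gives 4970 nM, the only value that is a number rather than a limit. For compound 2 this assay reports only the limit > 16000 nM. For compound 3 it reports only the limit > 8000 nM. For the measured compounds named here, the one measured step, an at least 1.6-fold higher number from compound 1 to compound 3 (0.20 log units; that floor lies within the scatter), replaces the anilino group itself and says nothing about substituents on its ring. Compound 4 `CCOc1ccc(NC2=CC(=O)c3nc4n(c3C2=O)[C@H]2OC[C@@H](O)[C@H]2OC4)cc1` differs from compound 1 by ethoxy in place of hydrogen on an aromatic carbon. Going by the values given here, no measured step bears on this change, so no shift beyond the scatter is expected, and the estimated step of a 1.2-fold lower number from compound 1 to compound 4 (0.09 log units; within the scatter) is small. Compound 4 is therefore expected to give about 4000 nM, between 1300 nM and 12000 nM.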

Compound 4, half-maximal inhibitory concentration: 3210 nM
Compound 4: the middle estimate sits 1.2-fold (0.10 log units) above what was measured; the range from low to high includes it.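

In this assay, putting ethoxy on the aromatic carbon of the anilino ring gives a 1.5-fold lower number from compound 1 to compound 4 (0.19 log units; within the scatter) and so makes no clear difference. Among the compounds shown here, this is the first look at a substituent on that ring, as the earlier step replaced the whole anilino group. None of the data shown explains why this result arises.

From the compounds shown here alone, whether another group at this place, such as an amine, a carboxylic acid or a longer chain than ethoxy, would move the number beyond the scatter remains open.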